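Biaryl amide acids: cytotoxicity notes on a bromo replacement

A few compounds are considered here, and "the series" means these few. Any claim that something is new, unique, unknown or untested is made for them only; others in the source may bear on it.

Compound 3 `CC(C)N(Cc1cccc(OCCCCCC(=O)O)c1)C(=O)c1ccc(-c2cccc(C(F)(F)F)c2)cc1` stands, like both other members, at a limit rather than a number. In an ADME assay on HEK293 cells (Homo sapiens) for cytotoxicity, read by CellTiter-Glo and resazurin assay, with a stated time of 72 h (a lower number here means that less compound is needed, a higher number that more compound is needed for the effect), compound 3 gives > 26000 nM, a limit of the assay. Compound 1 `CC(C)N(Cc1cccc(OCCCCCC(=O)O)c1)C(=O)c1ccc(-c2cccc(N(C)C)c2)cc1` gives in this assay > 26000 nM, also a limit. Compound 2 `COc1cccc(-c2ccc(C(=O)N(Cc3cccc(OCCCCCC(=O)O)c3)C(C)C)cc2)c1` gives in this assay > 20900 nM, again a limit. The steps a step that the two limits leave unreadable from compound 1 to compound 2, a step that the two limits leave unreadable from compound 1 to compound 3 and a step that the two limits leave unreadable from compound 2 to compound 3 are all unreadable, and the limit of > 20900 nM in this assay, at which 1 of the 3 values shown sits, together with the limit of > 26000 nM in this assay, at which 2 of the 3 values shown sit, is all the series offers. Compound 4 `CC(C)N(Cc1cccc(OCCCCCC(=O)O)c1)C(=O)c1ccc(-c2cccc(Br)c2)cc1` carries bromo in place of trifluoromethyl on an aromatic carbon. Among the compounds with values here, no measured step bears readably on this change, so no direction in this assay can be inferred. The expected step is a step that the limit leaves unreadable from compound 3 to compound 4, most probably ending again at a limit. Compound 4 is estimated at 30000 nM, between 15000 nM and 100000 nM.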

Compound 4, half-maximal effective concentration: > 26000 nM
Compound 4 was reported as a limit (the forecaster's own chance of this, stated with the estimate: 80%); the middle value does not contradict the limit.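

Compound 4 stands at a limit, as do compound 1, compound 2 and compound 3, and no step among these compounds can be read in this assay. Going by these compounds, whether dimethylamino, methoxy, trifluoromethyl and bromo differ at all in this assay stays open.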